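The source may hold more compounds than are shown below. What is called first, only, known or untested is meant among the compounds shown, and "the series" means these compounds.

Measured in an assay on cells for displacement of a labelled ligand from adenosine receptor A1 (Homo sapiens), with a stated time of 60 min, tested at 1 uM; on this read-out higher numbers stand for more inhibition at the one concentration tested (going by the name of the read-out) and lower numbers for less inhibition:

Compound 1 `CCOC(=O)C1=C(C)N/C(=N\C#N)NC1c1cccs1`: 26%
Compound 2 `CC1=C(C(=O)OC(C)C)C(c2ccsc2)N/C(=N/C#N)N1`: 11%
Compound 3 `CCOC(=O)C1=C(C)N/C(=N\C#N)NC1c1ccsc1`: 29%

Among these three numbers compound 3 holds the highest value. The step of a number 3 percentage points higher from compound 1 to compound 3 (within the scatter) lies within the scatter, so no order between these two compounds can be read; the step of a number 18 percentage points higher from compound 2 to compound 3 (beyond the scatter) lies beyond it. Compound 4 `CCOC(=O)C1=C(C)N/C(=N\C#N)NC1c1ccco1` has not been measured. It differs from compound 3 in one place: furan-2-yl in place of thiophen-3-yl on a saturated ring carbon. Among the measured compounds shown here, the only measured step that bears on this change is a number 3 percentage points higher from compound 1 to compound 3 (within the scatter), where one five-membered aromatic ring replaced another on the same saturated ring carbon without a shift beyond the scatter. For the measured compounds named here, no furan-bearing compound has been measured here. On that basis the expected step is a number 4 percentage points lower from compound 3 to compound 4 (within the scatter), with no shift beyond the scatter. Compound 4 is therefore estimated at 25%, in a range from 10% to 40%.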

Compound 4, a percentage reported as inhibition, at one concentration (the size of the read-out at that concentration, not a potency): 27%
Compound 4: the middle estimate sits 2 percentage points below what was measured; the range from low to high includes it.
By their numbers in this assay, from the lowest: compound 2; then compounds 1, 4 and 3 (each within the scatter of the next).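

In this assay, a ring with oxygen in place of sulfur at this saturated ring carbon gives a number 2 percentage points lower from compound 3 to compound 4 (within the scatter), and a number 1 percentage points higher from compound 1 to compound 4 (within the scatter). Thiophen-2-yl, thiophen-3-yl and furan-2-yl therefore cannot be told apart at this position, whichever hetero atom the five-membered aromatic ring carries. No evidence is available to explain this likeness.

Going by these compounds, what remains open is whether the number in this assay stays level with anything other than these five-membered aromatic rings at this position. A six-membered phenyl ring, a saturated cyclohexyl ring or a chain carrying an amine could each give a different answer.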